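A few compounds are considered here, and "the series" means these few. Any claim that something is new, unique, unknown or untested is made for them only; others in the source may bear on it.

In a functional assay on HeLa cells (Homo sapiens) for antiproliferative activity, read by CCK-8 assay, with a stated time of 72 h (on this read-out higher numbers stand for weaker inhibition of growth and lower numbers for stronger inhibition of growth), compound 1 (`CC[C@@H]1C(=O)N(C)c2cnc(-n3ccc4ccccc43)nc2N1C1CCCC1`) gives 33900 nM while compound 2 (`CCCNC(=O)c1ccc2c(ccn2-c2ncc3c(n2)N(C2CCCC2)[C@H](CC)C(=O)N3C)c1`) gives 238 nM and holds the lower of the two numbers. Compound 3 (`CC[C@@H]1C(=O)N(C)c2cnc(-n3ccc4cc(C(=O)NCC(C)C)ccc43)nc2N1C1CCCC1`) changes propyl to isobutyl (methyl in place of hydrogen on a saturated chain carbon bound to two saturated chain carbons), with methyl in place of hydrogen on a saturated chain carbon bound to two saturated chain carbons. Among the compounds with values here, the only measured step (a 140-fold lower number from compound 1 to compound 2 (2.15 log units; beyond the scatter)) brought in the whole propylcarbamoyl in place of hydrogen on an aromatic carbon, so it sets no size for one methyl, and no step beyond the scatter is expected in this assay for this change. The expected change (a 1.3-fold higher number from compound 2 to compound 3 (0.10 log units; within the scatter)) is therefore small. Compound 3 is estimated at 300 nM with a range of 100 nM to 900 nM expected.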

Compound 3, concentration for 50% growth inhibition: 3280 nM
Compound 3: middle estimate off by 11-fold (1.04 log units), on the low side; the measured number lies above the stated range.
By their numbers in this assay, from the lowest: compound 2; then compound 3; then compound 1.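

In this assay this chain proves sensitive to a very small change: a single methyl on a saturated chain carbon bound to two saturated chain carbons gives a 14-fold higher number from compound 2 to compound 3 (1.14 log units; beyond the scatter) and so costs much of the gain seen with propylcarbamoyl. Isobutylcarbamoyl still beats hydrogen on the aromatic carbon, with a 10-fold lower number from compound 1 to compound 3 (1.01 log units; beyond the scatter) as its step. No measured evidence explains the size of this methyl step.

What butylcarbamoyl or ethylcarbamoyl would give in place of propylcarbamoyl stays open, so the compounds shown cannot separate the branching from the added carbon.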